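The source may report more compounds than this note shows. Statements on the series, on what has been measured and on what is new or still open speak of the compounds shown alone.

Series notes. Of the compounds shown here, three have been measured in an assay on isolated protein for inhibition of protein deacetylase HDAC6 (Homo sapiens), read by fluorescence, with a stated time of 90 min; a lower number here means a stronger inhibitor, a higher number a weaker inhibitor. Compound 3 `CC(C)(C)n1nnnc1CNCc1ccc(C(=O)NO)cc1` gives 330 nM, the highest of the three numbers. Compound 1 `O=C(NO)c1ccc(CNC(c2ccccc2)c2nnnn2C2CCCCC2)cc1` gives 120 nM, and compound 2 `Cc1ccccc1C(=O)N(Cc1ccc(C(=O)NO)cc1)Cc1nnnn1C1CCCCC1` gives 60 nM; both of these lie below the value of compound 3 by more than the scatter, with compound 2 the further away. For the measured compounds named here, both compound 1 and compound 2 carry a cyclohexyl on the aromatic nitrogen where compound 3 carries tert-butyl, but each also differs from compound 3 in other parts of the molecule, so no single-change step between measured compounds is available in this set.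

Compound 4 `O=C(NO)c1ccc(CNCc2nnnn2C2CCCCC2)cc1` is not yet measured. It differs from compound 3 in one place: cyclohexyl in place of tert-butyl on an aromatic nitrogen. Without a direct step to lean on, the expectation rests on compound 1, which carries the same cyclohexyl and gives 120 nM, and on compound 2, which carries it too and gives 60 nM. For compound 4 the expected step is a 2.2-fold lower number from compound 3 to compound 4 (0.34 log units; beyond the scatter), a move toward a lower number, modest in size. For compound 4 in this assay the estimate is 150 nM, with a range from 60 nM to 400 nM.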

Compound 4, half-maximal inhibitory concentration: 120 nM
For compound 4 the middle estimate is 1.3-fold (0.10 log units) above the measured one; the range from low to high includes it.
By their numbers in this assay, from the lowest: compounds 2, 1 and 4 (each within the scatter of the next); then compound 3.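

For the compounds shown here, with the rest of the molecule held constant, the effect of cyclohexyl in place of tert-butyl on an aromatic nitrogen of the five-membered ring with 4 nitrogen can now be read directly in this assay as a 2.8-fold lower number from compound 3 to compound 4 (0.44 log units; beyond the scatter), a single-place comparison that no earlier pair offered. With cyclohexyl kept on that nitrogen, neither further group separates from hydrogen beyond the scatter: (2-methylphenyl)carbonyl on the amine nitrogen gives a 2.0-fold higher number from compound 2 to compound 4 (0.30 log units; within the scatter), and phenyl on the saturated chain carbon bound to an amine nitrogen and an aromatic carbon gives no change at the digits printed from compound 1 to compound 4 (within the scatter), so among these compounds the only step beyond the scatter is the change on the aromatic nitrogen. The data shown include no separate measurement that would explain this step.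

Still open, going by these compounds, is how other groups on the same aromatic nitrogen, such as cyclopentyl, a straight butyl chain or phenyl, would compare with cyclohexyl and tert-butyl. Also open, on these data alone, is whether phenyl on the chain carbon or (2-methylphenyl)carbonyl on the amine nitrogen would give the same reading with tert-butyl on the aromatic nitrogen.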